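Removing the ring methyl from two dibromopyrrole cores

The compounds below may be only part of what the source reports. "The series", "measured", "known", "first", "only" and "open" are said of these compounds alone.

The study compares two dibromopyrrole cores. Compound 1, `Cn1c(/C=C/C(=O)c2ccc[nH]2)cc(Br)c1Br`, gives 2110 nM in a functional assay on WRL68 cells (Homo sapiens) for cytotoxicity, read by MTT assay, with stated times of 6 h and 48 h; a higher number here means a weaker inhibitor, a lower number a stronger inhibitor. Compound 2, `O=C(/C=C/c1cc(Br)c(Br)[nH]1)c1ccc[nH]1`, is the same core with hydrogen in place of methyl on an aromatic nitrogen. For compound 2 this assay reports only a limit, >= 100000 nM. The step is an at least 47-fold higher number from compound 1 to compound 2 (1.67 log units; beyond the scatter), which reflects (the limit of >= 100000 nM in this assay, at which 2 of the 3 values shown sit). Compound 3, `Cn1c(-c2cc(-c3ccccc3O)no2)cc(Br)c1Br`, carries a different large group; the difference between the two cores is not broken down here. For compound 3 this assay likewise reports only a limit, >= 100000 nM. Compound 4, `Oc1ccccc1-c1cc(-c2cc(Br)c(Br)[nH]2)on1`, differs from compound 3 by hydrogen in place of methyl on an aromatic nitrogen; the ring atom next to the place bears a large group rather than a group of 9 heavy atoms, so this is the same kind of change. Since compound 3 already sits at the limit, compound 4 is expected to stay there, with an estimated step of a number no higher from compound 3 to compound 4 (the limit leaves the size open) and an expected value of 100000 nM.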

Compound 4, half-maximal inhibitory concentration: >= 100000 nM
Compound 4 gave a limit, no number (the forecaster's own chance of this, stated with the estimate: 85%); the middle value sits exactly at the limit.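

The step from compound 3 to compound 4 cannot be read, because each compound gives only a limit: the limit of >= 100000 nM in this assay, at which 3 of the 4 values shown sit. The compounds shown leave open whether hydrogen in place of methyl on an aromatic nitrogen changes the number at all in the core of compound 3.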